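The compounds below may be only part of what the source reports. "The series", "measured", "known", "first", "only" and "open" are said of these compounds alone.

For the measured compounds named here, compound 1 `CC(=O)OCCO[C@H](CC=C(C)C)C1=CC(=O)c2c(O)ccc(O)c2C1=O` gives 41500 nM in a functional assay on HeLa cells (Homo sapiens) for cytotoxicity, read by MTT assay (a lower number here means a stronger inhibitor, a higher number a weaker inhibitor), the highest of the three numbers measured so far. Compound 2 `CCC(C)(O)CC(=O)O[C@H](CC=C(C)C)C1=CC(=O)c2c(O)ccc(O)c2C1=O` gives 25200 nM and compound 3 `CC[C@](C)(O)CC(=O)O[C@H](CC=C(C)C)C1=CC(=O)c2c(O)ccc(O)c2C1=O` gives 30200 nM. The steps of a 1.6-fold lower number from compound 1 to compound 2 (0.22 log units; within the scatter) and a 1.4-fold lower number from compound 1 to compound 3 (0.14 log units; within the scatter) both exchange the whole 2-acetoxyethyl group, and the step of a 1.2-fold higher number from compound 2 to compound 3 (0.08 log units; within the scatter) rests only on (the fact that one of compounds 2 and 3 is drawn with a defined configuration and the other without, at the place where they differ). Compound 4 `COCCO[C@H](CC=C(C)C)C1=CC(=O)c2c(O)ccc(O)c2C1=O` differs from compound 1 by methyl in place of acetyl on an oxygen on a saturated carbon. Going by the values given here, no measured step alters the acetyl on its own, and every step seen so far stays within the scatter, so a change beyond the scatter is not expected for this exchange either. Compound 4 is therefore expected to give 40000 nM in this assay, between 15000 nM and 110000 nM, which corresponds to a 1.0-fold lower number from compound 1 to compound 4 (0.02 log units; within the scatter).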

Compound 4, half-maximal inhibitory concentration: 62400 nM
The estimate for compound 4 lay 1.6-fold (0.19 log units) below the measured number; the range from low to high includes it.
By their numbers in this assay, from the lowest: compounds 2, 3, 1 and 4 (each within the scatter of the next, the first and the last beyond it).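

Methyl in place of acetyl on an oxygen on a saturated carbon, the first exchange to touch the acetyl on its own, gives a 1.5-fold higher number from compound 1 to compound 4 (0.18 log units; within the scatter) and so leaves the number within the scatter. For the compounds shown here, the 2-methoxyethyl group in place of (2-hydroxy-2-methylbutyl)carbonyl gives a 2.1-fold higher number from compound 3 to compound 4 (0.32 log units; beyond the scatter) and a 2.5-fold higher number from compound 2 to compound 4 (0.39 log units; beyond the scatter) as the first steps to pass the scatter, both modest. Nothing available accounts for these differences.

From the compounds shown here alone, whether an amine or a carboxylic acid in place of the methyl on this oxygen would shift the number stays open. So does the effect of a longer chain there.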